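Swapping 3,4-dichlorobenzyl for 3-methoxybenzyl on a shared core

This account rests on a few compounds, and the source may have more. Where it says the series, first, only, none or still open, it means among the compounds named here.

In a functional assay on K562 cells (Homo sapiens) for antiproliferative activity, read by MTT assay, with a stated time of 48 h (a lower number here means a stronger inhibitor, a higher number a weaker inhibitor), compound 1 `Cc1ccc(-c2ccc3c(c2)C(=O)C(=O)N3)cc1` gives > 10000 nM, a limit of the assay and not a number. Compound 2 `O=C1Nc2ccc(-c3ccc(C(F)(F)F)cc3)cc2C1=O` gives > 10000 nM, again a limit. Within the data shown here, compound 3 `COc1ccc(-c2ccc3c(c2)C(=O)C(=O)N3Cc2ccc(Cl)c(Cl)c2)cc1` gives 430 nM, the only true number among the three measurements.

Compound 4 `COc1ccc(-c2ccc3c(c2)C(=O)C(=O)N3Cc2cccc(OC)c2)cc1` keeps the core of compound 3 and changes one group: 3-methoxyphenyl in place of 3,4-dichlorophenyl on a saturated chain carbon bound to an amide-type nitrogen in a ring. Cut one bond further out, this reads as 3,4-dichlorobenzyl to 3-methoxybenzyl, on a saturated chain carbon bound to an amide-type nitrogen in a ring.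

Among the measured compounds shown here, the only measured step between close neighbours is a step that the two limits leave unreadable from compound 1 to compound 2. For the measured compounds named here, it gives no size, and it concerns trifluoromethyl in place of methyl on an aromatic carbon, a different place from the one that changes here. Going by the values given here, no measured step therefore bears directly on this change. The expectation rests on compound 3 alone, at 430 nM, and no direction can be read from the data.

In this assay the expected change is a 1.2-fold lower number from compound 3 to compound 4 (0.09 log units; within the scatter), which is not expected to lie beyond the usual scatter. For compound 4 the estimated value is 350 nM, with an expected range from 90 nM to 1500 nM, kept wide for want of a measured step at this place.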

Compound 4, half-maximal inhibitory concentration: 680 nM
The estimate for compound 4 lay 1.9-fold (0.29 log units) below the measured number, within the range that was stated.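

In this assay, among these compounds, the change from 3,4-dichlorophenyl to 3-methoxyphenyl on a saturated chain carbon bound to an amide-type nitrogen in a ring gives a 1.6-fold higher number from compound 3 to compound 4 (0.20 log units; within the scatter), the first readable step at this position. The assay therefore does not tell these two benzyl groups apart: both chlorine atoms leave and a methoxy group enters, adding one hydrogen-bond acceptor where the leaving group had none, with no change beyond the scatter. Among the compounds shown here, the earlier compounds could not show this, since the only step among them concerns a different place and cannot be read, although the finding still rests on this single pair.

From the compounds shown here alone, it remains open whether the same swap would read alike on a core carrying methyl or trifluoromethyl in place of the methoxy group of compound 3 and compound 4, and how an amine or a carboxylic acid on a longer chain would fare at this nitrogen. Compound 1 and compound 2 offer no help here, as each sits at a limit of the assay and not at a number: the limit of > 10000 nM in this assay, at which 2 of the 4 values shown sit.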